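Trifluoromethoxy in Place of Methyl on the Fused Ring

A few compounds are considered here, and "the series" means these few. Any claim that something is new, unique, unknown or untested is made for them only; others in the source may bear on it.

Compound 2 `Cc1ccc2c(c1)/C(=C\C(=O)OC(C)(C)C)C(=O)N2` and compound 1 `CC(C)(C)OC(=O)/C=C1/C(=O)N(Cc2ccccc2)c2ccccc21` are the two measured compounds. In a functional assay on HL-60 cells (Homo sapiens) for inhibition, read by CCK-8 assay, with a stated time of 72 h, tested at 20 uM (a lower number here means less inhibition of growth, a higher number more inhibition of growth at the concentration tested), compound 2 gives 94.6%, and compound 1 gives 91.7%; these two numbers lie within the usual scatter of each other, so neither stands apart. Compound 3 `CC(C)(C)OC(=O)/C=C1/C(=O)Nc2ccc(OC(F)(F)F)cc21` differs from compound 2 by trifluoromethoxy in place of methyl on an aromatic carbon. Going by the values given here, no step between measured compounds exists to guide this change, so a shift no larger than the usual scatter is expected, in either direction, which means an expected step of a number 4.6 percentage points lower from compound 2 to compound 3 (within the scatter). Compound 3 is therefore expected to give 90%, with a range from 75% to 98%.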

Compound 3, percent growth inhibition at one concentration: 95.9%
Estimate against measurement, compound 3: 5.9 percentage points below, and the stated range covers the measured number.
By their numbers in this assay, from the lowest: compounds 1, 2 and 3 (each within the scatter of the next).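

In this assay, trifluoromethoxy in place of methyl on this aromatic carbon gives a number 1.3 percentage points higher from compound 2 to compound 3 (within the scatter). The position therefore accepts this change without a shift beyond the scatter at the concentration tested, which compound 1, carrying neither group here, could not show. Nothing available explains this outcome.

From the compounds shown here alone, whether an amine, a carboxylic acid or a longer chain on this carbon would give a similar number remains open. A single concentration also leaves open how compound 2 and compound 3 would compare at lower concentrations.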